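This account rests on a few compounds, and the source may have more. Where it says the series, first, only, none or still open, it means among the compounds named here.

Three compounds have numbers in a functional assay on the whole organism with Mus musculus as the target; a higher number here means a larger maximal response, a lower number a smaller maximal response. Compound 1 `CCCCCCCCCCn1c(=O)n(C2OC(CO)[C@@H](O)[C@H]2O)c2nc(N)nc(O)c21` gives 0% in this assay, the lowest of the three. Compound 2 `CCCn1c(=O)n(C2CCC(CO)O2)c2nc(NC(=O)C(C)(C)C)nc(O)c21` gives 4%, within the scatter of compound 1. Compound 3 `C=CCn1c(=O)n([C@H]2CO[C@@H](CO)C2)c2nc(N)nc(O)c21` gives 16%, beyond the scatter above compound 1. Within the data shown here, no two of these differ in one place only, so no single step between measured compounds is at hand; the three numbers together show only that the whole group sits at the low end of the range, with compound 3 the one reading that clears the scatter.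

Compound 4 `CN(C)CCCn1c(=O)n(C2OC(CO)[C@@H](O)[C@H]2O)c2nc(N)nc(O)c21` differs from compound 1 as follows: dimethylamino in place of heptyl on a saturated chain carbon, three bonds along the chain from an aromatic nitrogen. The shared core of compound 1 is kept unchanged; only the chain is cut back and capped. Nothing measured tells how a dimethylamino in place of heptyl moves this assay, and the three readings give no trend to lean on. The expected step, a number 8 percentage points higher from compound 1 to compound 4 (within the scatter), is therefore small, either direction or none beyond the scatter. For compound 4 the expected maximal response in this assay is 8%, with a range from 0% to 25%.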

Compound 4, largest response reached (reported as maximal response), in percent of the reference or control that the assay uses: 63%
Compound 4: the middle estimate sits 55 percentage points below what was measured, outside the stated range (above it).
By their numbers in this assay, from the lowest: compounds 1 and 2 (each within the scatter of the next); then compound 3; then compound 4.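

Decyl to 3-(dimethylamino)propyl on the shared core of compound 1 is the only single change that can be read in this assay so far, and it gives a number 63 percentage points higher from compound 1 to compound 4 (beyond the scatter) with the rest of the structure held fixed. The earlier compounds shown here all sat at the low end and differed in several places at once, so they could not show that this chain alone can carry the maximal response far upward. The step holds for this one pair only, and no measurement at hand accounts for it.

The step shortens the chain and adds the dimethylamino end together, so the share of each remains unresolved. A plain propyl chain on this core would separate the two, and a pyrrolidine or morpholine at the chain end, or a longer chain carrying the same dimethylamino, would show how far the change extends.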